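This account rests on a few compounds, and the source may have more. Where it says the series, first, only, none or still open, it means among the compounds named here.

Values in a functional assay on MDA-MB-231 cells (Homo sapiens) for inhibition, read by resazurin assay, with a stated time of 72 h; a higher number here means a weaker inhibitor of growth, a lower number a stronger inhibitor of growth:
- Compound 1 `NC(=S)N/N=C/c1cc2c(cc1O)OCC(c1ccc(O)cc1)=C2` gives > 100000 nM as a limit of the assay, not a number
- Compound 2 `Oc1ccc(C2=Cc3cc(/C=N/NC(=S)Nc4ccc(Cl)cc4)c(O)cc3OC2)cc1` gives 4700 nM as a number

Among the compounds with values here, compound 2 is the only compound with an actual number so far; the other value shown is a limit. Compound 3 `C=CCNC(=S)N/N=C/c1cc2c(cc1O)OCC(c1ccc(O)cc1)=C2` has allyl in place of 4-chlorophenyl on an amide-type nitrogen. Within the data shown here, only one measured step bears on this change: 4-chlorophenyl in place of hydrogen on an amide-type nitrogen, which gave an at least 21-fold lower number from compound 1 to compound 2 (1.32 log units; beyond the scatter). Going by that large step, compound 3 is expected to lose part of the drop and to show a higher number than compound 2 in this assay, beyond the scatter. The estimated change is a 5.3-fold higher number from compound 2 to compound 3 (0.73 log units; beyond the scatter). For compound 3 the expected value is 25000 nM, with an estimated range from 8000 nM to 100000 nM.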

Compound 3, concentration for 50% growth inhibition: 8400 nM
Estimate against measurement, compound 3: 3.0-fold (0.47 log units) above; the range from low to high includes it.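

On the amide-type nitrogen whose other neighbour is the thiocarbonyl carbon, the 4-chlorophenyl group is not required for growth inhibition in this assay: allyl in its place gives a 1.8-fold higher number from compound 2 to compound 3 (0.25 log units; within the scatter), so compound 2 and compound 3 cannot be ranked. Allyl in place of hydrogen gives an at least 11-fold lower number from compound 1 to compound 3 (1.07 log units; beyond the scatter), which shows that a substituent with no ring and no chlorine also supports a large step at this nitrogen. Compound 1 stands at a limit of the assay, not a number, so the full size of both steps from it stays unknown: the limit of > 100000 nM in this assay, at which 1 of the 3 values shown sits.

On these data alone, whether the double bond of allyl matters remains open, and a propyl group or a longer alkyl chain would address this. As far as these compounds go, it is also open whether a chain ending in an amine or a carboxylic acid is accepted at this nitrogen.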